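A few compounds are considered here, and "the series" means these few. Any claim that something is new, unique, unknown or untested is made for them only; others in the source may bear on it.

Measured so far in a functional assay on NCI-H460 cells (Homo sapiens) for inhibition, with a stated time of 72 h; a higher number here means a weaker inhibitor, a lower number a stronger inhibitor:

Compound 1 `COc1ccc(S(=O)(=O)N2CCc3cccc(-c4ccc(F)cc4)c32)cc1` gives 95.5 nM.
Compound 2 `COc1ccc(S(=O)(=O)N2CCc3cccc(-c4ccc(F)nc4)c32)cc1` gives 135 nM.
Compound 3 `COc1ccc(S(=O)(=O)N2CCc3cccc(-c4c(F)c(F)c(F)c(F)c4F)c32)cc1` gives 4760 nM.

In this assay compound 2 stands second highest of the three numbers. Going by the values given here, its nearest neighbour is compound 1, which sits within the scatter of it, and its furthest is compound 3, which lies far above it; with no single-point step between compound 2 and compound 3, only the two numbers themselves speak, and they show that the pentafluorophenyl bearer is the weak one of this group.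

The change to compound 4 `COc1ccc(S(=O)(=O)N2CCc3cccc(-c4ccncc4)c32)cc1` is pyridin-4-yl in place of 6-fluoropyridin-3-yl on an aromatic carbon. Among the compounds with values here, the one measured step that bears on it is the swap of the aryl partner between compound 1 and compound 2, a 1.4-fold higher number from compound 1 to compound 2 (0.15 log units; within the scatter), which stayed within the scatter. Nothing measured here tells what moving the nitrogen or dropping the single fluorine does on its own, and the heavily fluorinated compound 3 is a different kind of change. On that basis no step beyond the scatter is expected in this assay for compound 4, with the estimated step from compound 2 being a 1.1-fold higher number from compound 2 to compound 4 (0.05 log units; within the scatter).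

Compound 4 is estimated at 150 nM, with a range from 60 nM to 400 nM.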

Compound 4, half-maximal inhibitory concentration: 101 nM
Estimate against measurement, compound 4: 1.5-fold (0.17 log units) above; the measured number falls inside the stated range.
By their numbers in this assay, from the lowest: compounds 1, 4 and 2 (each within the scatter of the next); then compound 3.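

In this assay, pyridin-4-yl in place of 6-fluoropyridin-3-yl gives a 1.3-fold lower number from compound 2 to compound 4 (0.13 log units; within the scatter) and pyridin-4-yl in place of 4-fluorophenyl gives a 1.1-fold higher number from compound 1 to compound 4 (0.02 log units; within the scatter) on this aromatic carbon, and both steps stay within the scatter. Going by these compounds alone, every earlier compound carried fluorine on this aryl group, so compound 4 adds the first sign that a six-membered aromatic ring without fluorine can stand here with no step beyond the scatter, and that the ring nitrogen can sit as it does in pyridin-4-yl as well as in 6-fluoropyridin-3-yl; compound 3 remains the one compound of the four that lies apart from this group. No evidence beyond these numbers bears on the result.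

On these data alone, whether this flat picture holds for a saturated ring such as piperidin-4-yl, or for an aryl ring bearing a carboxylic acid or an aminomethyl group, stays open. Also open, as far as these compounds go, is how the number moves between a single fluorine and the pentafluorophenyl group of compound 3, which gives 4760 nM in this assay; a difluorophenyl or trifluorophenyl group would bear on that.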